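This account rests on a few compounds, and the source may have more. Where it says the series, first, only, none or still open, it means among the compounds named here.

Working notes on the series. Among the measured compounds shown here, compound 1 `COc1cc(/C(Cl)=C/C=C(\C#N)C(=O)c2c[nH]c3ccccc23)cc(OC)c1OC` is the only member with a number in an ADME assay on Vero cells (Chlorocebus sabaeus) for cytotoxicity, read by sulforhodamine B assay, with a stated time of 48 h; a higher number here means a weaker inhibitor of growth, a lower number a stronger inhibitor of growth: in that assay compound 1 gives 16200 nM, so it stands alone on the scale and cannot be ranked against any other entry. For the measured compounds named here, compound 2 `COc1ccc(/C(Cl)=C/C=C(\C#N)C(=O)c2c[nH]c3ccc(Br)cc23)cc1` has no result in this assay and is recorded as "not determined" (no result reported), so no second point is available and no measured step exists anywhere in the set. Compound 3 `COc1cc(/C(Cl)=C/C=C(\C#N)C(=O)c2c[nH]c3ccc(Br)cc23)cc(OC)c1OC` differs from compound 1 in one place on the shared core: bromo in place of hydrogen on an aromatic carbon. Going by the values given here, with no measured pair showing what such a change does in this assay, the expected step from compound 1 to compound 3 is set close to zero, at a 1.4-fold lower number from compound 1 to compound 3 (0.13 log units; within the scatter), with only a slight lean toward a lower number, which would mean growth inhibition no weaker than that of compound 1. Compound 3 is accordingly estimated at 12000 nM, in the range 4000 nM to 40000 nM.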

Compound 3, concentration for 50% growth inhibition: 7600 nM
Compound 3: the middle estimate sits 1.6-fold (0.20 log units) above what was measured, within the range that was stated.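

In this assay, among the compounds shown here, the change from 1H-indol-3-yl to 5-bromo-1H-indol-3-yl gives a 2.1-fold lower number from compound 1 to compound 3 (0.33 log units; beyond the scatter) and so provides the first measured step. This aromatic carbon of the shared core therefore accepts bromo with no loss of growth inhibition, and the modest shift is toward stronger inhibition, though the claim rests on this single pair. Nothing measured here accounts for the step.

From the compounds shown here alone, whether an amine or a carboxylic acid on the same carbon would move the number in the same direction, or reverse it, remains open. Also open, going by these compounds, is whether bromo gives a step of similar size elsewhere, as compound 2 has no number to compare and one pair cannot show how general the change is.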